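Removing a Side-Chain Hydroxyl: From Compound 2 to Compound 4

The source may report more compounds than this note shows. Statements on the series, on what has been measured and on what is new or still open speak of the compounds shown alone.

compound 1, `COC(C)(C)/C=C/C/C(C)=C/Cc1c(O)ccc2c1O[C@H](c1ccc(O)cc1)CC2=O`: > 10000 nM in a functional assay on HeLa S3 cells (Homo sapiens) for cytotoxicity, read by MTT assay (a higher number here means a weaker inhibitor, a lower number a stronger inhibitor), a limit of the assay
compound 2, `C=C(C)C(O)CC/C(C)=C/Cc1c(O)ccc2c1O[C@H](c1ccc(O)cc1)CC2=O`: > 10000 nM in this assay, a limit of the assay
compound 3, `CC1=CCC(O)C(C)(C)C1Cc1c(O)ccc2c1O[C@H](c1ccc(O)cc1)CC2=O`: > 10000 nM in this assay, a limit of the assay

Compound 2 stands where every measured compound here stands: at the limit of this assay, so that no number is known for it, only that it lies past the limit. Going by the values given here, the two steps that touch it, a step that the two limits leave unreadable from compound 1 to compound 2 and a step that the two limits leave unreadable from compound 2 to compound 3, cannot be read for the same reason, and the only evidence across the set is the limit of > 10000 nM in this assay, at which 3 of the 3 values shown sit. Compound 4, `CC(C)=CCC/C(C)=C/Cc1c(O)ccc2c1O[C@H](c1ccc(O)cc1)CC2=O`, is reached from compound 2 by a single change: 2-methylprop-1-en-1-yl in place of 1-hydroxy-2-methylprop-2-en-1-yl on a saturated chain carbon, two bonds along the chain from a double-bonded chain carbon. Neither measured step bears on this change in a readable way, so no direction and no size can be drawn from them, and the plainest expectation is that compound 4 also remains past the limit. The step from compound 2 to compound 4 is therefore expected to be a step that the limit leaves unreadable from compound 2 to compound 4. Compound 4 is estimated at 20000 nM, within a range from 5000 nM to 100000 nM.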

Compound 4, half-maximal inhibitory concentration: > 10000 nM
Compound 4 gave a limit, no number; the forecaster's own chance of this, stated with the estimate: 80%; the middle value lies beyond the limit too.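

Going by these compounds alone, no step from compound 1, compound 2 or compound 3 to compound 4 can be read, since all four compounds give only a limit and no number: the limit of > 10000 nM in this assay, at which 4 of the 4 values shown sit. The compounds shown leave open how far past that limit each one lies, and whether any side chain on the shared core would give a readable value.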